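The compounds below may be only part of what the source reports. "The series", "measured", "known", "first", "only" and "open" are said of these compounds alone.

Measured so far:
compound 1 `CCc1ccc(-c2nc3c(c(C)nn3-c3ccccc3)c(-c3ccccc3C)c2C#N)cc1`; in an ADME assay on BJ cells (Homo sapiens) for cytotoxicity, with a stated time of 72 h (a higher number here means that more compound is needed for the effect, a lower number that less compound is needed), compound 1 gives only a limit, > 20000 nM.
compound 2 `Cc1cccc(-c2nc3c(c(C)nn3-c3ccccc3)c(-c3ccccc3O)c2C#N)c1`; in this assay compound 2 gives only a limit, > 20000 nM.

Compound 2 stands at the edge of what the measurement can report: its value is a limit of the assay, not a number, so it cannot be ranked against anything. the limit of > 20000 nM in this assay, at which 2 of the 2 values shown sit, shows that both measured compounds share this situation. The unmeasured compound 3 `Cc1nn(-c2ccccc2)c2nc(-c3ccc(F)cc3)c(C#N)c(-c3ccccc3O)c12` differs from compound 2 in a single place: 4-fluorophenyl in place of 3-methylphenyl on an aromatic carbon. Within the data shown here, no step between two measured compounds exists to show what a change of this kind does in this assay, and the two limits give no direction at all. Compound 3 is therefore expected to come out near 25000 nM, somewhere between 10000 nM and 60000 nM, and most likely to be reported again only as a limit. The step that the limit leaves unreadable from compound 2 to compound 3 is expected to be none beyond the scatter.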

Compound 3, half-maximal effective concentration: > 20000 nM
Compound 3: only a limit was reported; the forecaster's own chance of this, stated with the estimate: 85%; the middle value is on the limit's open side.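

Compound 2 and compound 3 each give only a limit in this assay, so no step between them can be read, because all the values shown stop at the same point: the limit of > 20000 nM in this assay, at which 3 of the 3 values shown sit.

The compounds shown leave open what concentration of any of them would reach the half-maximal effect, and what 4-fluorophenyl in place of 3-methylphenyl does to that concentration.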